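Chloro to methoxy: from compound 2 to compound 3

This account rests on a few compounds, and the source may have more. Where it says the series, first, only, none or still open, it means among the compounds named here.

Measured in a functional assay on the whole organism for inhibition, with Rattus norvegicus as the target; on this read-out lower numbers stand for stronger inhibition and higher numbers for weaker inhibition:
- compound 1 `O=C1ON=C(c2cccs2)/C1=C/c1ccc(O)c(O)c1`: 3400 nM
- compound 2 `O=C1ON=C(c2cccs2)/C1=C/c1ccc(Cl)cc1`: 6200 nM

Compound 2 at 6200 nM and compound 1 at 3400 nM lie within the scatter of each other, so compound 2 does not stand apart on these numbers. Compound 3 `COc1ccc(/C=C2\C(=O)ON=C2c2cccs2)cc1` is the next entry and keeps the shared core of compound 2. Going by the values given here, the one change is methoxy in place of chloro on an aromatic carbon, para to a large group: methoxy in place of chloro on an aromatic carbon. Among the compounds with values here, no measured pair shows a change at this place, so the data give no direct size for such a step. The two close values offer only a weak guide, and no step beyond the scatter is expected in this assay, in either direction. The estimated change is a 1.1-fold lower number from compound 2 to compound 3 (0.05 log units; within the scatter). For compound 3 the estimate is 5500 nM, with an expected range of 2300 nM to 13000 nM.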

Compound 3, half-maximal inhibitory concentration: 2500 nM
The estimate for compound 3 lay 2.2-fold (0.34 log units) above the measured number, within the range that was stated.
By their numbers in this assay, from the lowest: compounds 3, 1 and 2 (each within the scatter of the next, the first and the last beyond it).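

Going by these compounds alone, this is the first step that can be read at a single place. In this assay methoxy in place of chloro on an aromatic carbon, para to a large group, gives a change beyond the scatter (a 2.5-fold lower number from compound 2 to compound 3 (0.39 log units; beyond the scatter)), so this position does respond to the group it carries, though the step is modest and rests on one pair. No measurement on hand accounts for the step, and its origin stays unassigned.

Still open, as far as these compounds go, is whether the step belongs to methoxy alone or extends to other groups at this place, such as an amine, a carboxylic acid or a longer chain like ethoxy. The compounds shown also leave open how far any such change carries over to other substituents on the shared core.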